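A few compounds are considered here, and "the series" means these few. Any claim that something is new, unique, unknown or untested is made for them only; others in the source may bear on it.

Going by the values given here, compound 2 `CCc1ncncc1-c1nc2cc(F)c(F)cc2n1C1CC1` gives the lowest number of the two values so far in an assay on cells for inhibition of cytochrome P450 11B2, mitochondrial (Homo sapiens), read by HPLC, with a stated time of 90 min; on this read-out higher numbers stand for weaker inhibition and lower numbers for stronger inhibition: compound 2 gives 8 nM, while compound 1 `Fc1cc2nc(-c3cncnc3)n(C3CC3)c2cc1F` gives 22 nM. The step between them, a 2.8-fold lower number from compound 1 to compound 2 (0.44 log units; beyond the scatter), comes from ethyl in place of hydrogen on an aromatic carbon and lies beyond the scatter.

Compound 3 `CC(C)c1ncncc1-c1nc2cc(F)c(F)cc2n1C1CC1` has not yet been measured. It differs from compound 2 by methyl in place of hydrogen on a saturated chain carbon bound to an aromatic carbon and a saturated chain carbon; cut one bond further out, the same difference reads ethyl to isopropyl.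

Among the compounds with values here, only one measured step bears on this change: the one from compound 1 to compound 2, where adding the ethyl group at this position on the core lowered the number modestly. Nothing measured shows what a further methyl on that saturated chain carbon does. A further small lowering, or no change beyond the scatter, seems about equally plausible for compound 3.

Compound 3 is therefore expected to give about 6 nM in this assay, within a range from 2 nM to 20 nM, which would mean an estimated step of a 1.3-fold lower number from compound 2 to compound 3 (0.12 log units; within the scatter).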

Compound 3, half-maximal inhibitory concentration: 5 nM
Compound 3: the middle estimate sits 1.2-fold (0.08 log units) above what was measured; the measured number falls inside the stated range.
By their numbers in this assay, from the lowest: compounds 3 and 2 (each within the scatter of the next); then compound 1.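

In this assay the methyl that turns ethyl into isopropyl on the saturated chain carbon gives a 1.6-fold lower number from compound 2 to compound 3 (0.20 log units; within the scatter) and so stays within the scatter, which means that ethyl and isopropyl cannot be told apart at this position on this read-out. The earlier pair had shown only that ethyl could replace hydrogen on the aromatic carbon; isopropyl in place of that hydrogen gives a 4.4-fold lower number from compound 1 to compound 3 (0.64 log units; beyond the scatter) and lies beyond the scatter, so the lowering seen with ethyl is still present once the further methyl is added. Nothing available here explains either step.

Whether this tolerance continues with a tert-butyl group or a longer chain, or ends with an amine at the same place, stays open, as the compounds shown carry only hydrogen, ethyl and isopropyl there. As far as these compounds go, how the three compounds behave on any enzyme other than this one also stays open, as all their values come from this single read-out.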